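Changing the Aryl Group on the Ring Nitrogen

A few compounds are considered here, and "the series" means these few. Any claim that something is new, unique, unknown or untested is made for them only; others in the source may bear on it.

Measured compounds:
compound 1, `N#CC1=C(N)Oc2c(c3nc4ccccc4nc3c3ccccc23)C12C(=O)N(Cc1cnnn1-c1ccc(F)cc1)c1ccccc12`, in a functional assay on HCT-116 cells (Homo sapiens) for antiproliferative activity, read by MTT assay, with a stated time of 48 h (on this read-out lower numbers stand for stronger inhibition and higher numbers for weaker inhibition), gives > 50000 nM.
compound 2, `Cc1ccc(-n2nncc2CN2C(=O)C3(C(C#N)=C(N)Oc4c3c3nc5ccccc5nc3c3ccccc43)c3ccccc32)cc1Cl`, gives > 50000 nM.
compound 3, `N#CC1=C(N)Oc2c(N)cc3nc4ccccc4nc3c2C12C(=O)N(Cc1cnnn1-c1ccccc1Br)c1ccccc12`, gives 12400 nM.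

The value shown for compound 1 is a limit of this assay and not a number. The same holds for compound 2, whose value is also only a limit. For that reason the step that the two limits leave unreadable from compound 1 to compound 2 cannot be read. For the measured compounds named here, compound 3 stands apart as the one compound with a measured number: in this assay compound 3 gives 12400 nM, below the limit of > 50000 nM in this assay, at which 2 of the 3 values shown sit, at which the other two values rest.

Compound 4, `CCc1cccc(C)c1-n1nncc1CN1C(=O)C2(C(C#N)=C(N)Oc3c(N)cc4nc5ccccc5nc4c32)c2ccccc21`, has not yet been measured. It differs from compound 3 by 2-ethyl-6-methylphenyl in place of 2-bromophenyl on an aromatic nitrogen. Going by the values given here, no measured step gives a readable size for a change at this aromatic nitrogen; the only such step, a step that the two limits leave unreadable from compound 1 to compound 2, is hidden by the two limits. With nothing measured to push the expectation either way, compound 4 is expected to stay close to compound 3, and the step of a 1.2-fold higher number from compound 3 to compound 4 (0.08 log units; within the scatter) is expected to fall within the scatter of repeated measurements. Compound 4 is therefore estimated at 15000 nM, with a range from 5000 nM to 50000 nM.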

Compound 4, half-maximal inhibitory concentration: > 50000 nM
Compound 4: only a limit was reported (the forecaster's own chance of this, stated with the estimate: 25%); middle value at least 3.3-fold (0.52 log units) from the limit.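

In this assay, for the compounds shown here, putting 2-ethyl-6-methylphenyl in place of 2-bromophenyl on the aromatic nitrogen gives an at least 4.0-fold higher number from compound 3 to compound 4 (0.60 log units; beyond the scatter), the first step at this position whose size can be read at all, since the step between the two earlier compounds on their different core cannot be read. It shows that, on the core of compound 3, the aryl group on this nitrogen is not a neutral choice in this read-out, although this rests on a single pair of compounds. Going by these compounds alone, the value of compound 4 is only a limit of the assay, the same one that compound 1 and compound 2 reach, which leaves compound 3 as the only compound with a measured number: the limit of > 50000 nM in this assay, at which 3 of the 4 values shown sit.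

The step combines the loss of bromine with the arrival of ethyl and methyl, so the compounds shown cannot tell which part of the change accounts for the shift, or how far it really extends past the limit. They also leave open how an unsubstituted phenyl, or an aryl group carrying an amine or a carboxylic acid, would behave on this nitrogen.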